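The source may report more compounds than this note shows. Statements on the series, on what has been measured and on what is new or still open speak of the compounds shown alone.

Working notes on the series built on the shared core of compound 1 `COc1ccc(/C=C\C(=O)O)c(OCc2cn(-c3ccc(NC(=O)c4ccccc4)cc3)nn2)c1CC=C(C)C`. For the measured compounds named here, in a functional assay on NCI-H322 cells (Homo sapiens) for cytotoxicity, read by MTT assay, with a stated time of 24 h (a lower number here means a stronger inhibitor, a higher number a weaker inhibitor), compound 1 gives 17200 nM, a weak result that is the only number available for the series. Going by the values given here, compound 2 `COc1ccc(-n2cc(COc3c(/C=C\C(=O)O)ccc(OC)c3CC=C(C)C)nn2)cc1` gives "not determined" (no result reported) in this assay, so it stands without a single number, and compound 3 `COc1ccc(/C=C\C(=O)O)c(OCc2cn(-c3ccccc3C(=O)N3CCC(O)C3)nn2)c1CC=C(C)C` likewise gives "not determined" (no result reported), with no result reported, so there is no measured step from which the weight of a change on the aromatic nitrogen can be read. Compound 4 `COc1ccc(/C=C\C(=O)O)c(OCc2cn(-c3nc4ccccc4s3)nn2)c1CC=C(C)C` has not been measured; it differs from compound 2 by 1,3-benzothiazol-2-yl in place of 4-methoxyphenyl on an aromatic nitrogen. No step beyond the scatter is expected from this change, and compound 4 is expected to remain near the weak range shown by compound 1. For compound 4 in this assay the half-maximal inhibitory concentration is estimated at 20000 nM, with a range from 7000 nM to 60000 nM.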

Compound 4, half-maximal inhibitory concentration: 23000 nM
Beside the measured number, compound 4's estimate is 1.2-fold (0.06 log units) below it, within the range that was stated.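

No step can be read from compound 4, as compound 2 stands without a single number, and no evidence bears on this result. The compounds shown leave open how 1,3-benzothiazol-2-yl compares with 4-methoxyphenyl on the aromatic nitrogen.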